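From 1,3-benzothiazol-2-yl to 1,3,4-thiadiazol-2-yl on a sulfur

The source may report more compounds than this note shows. Statements on the series, on what has been measured and on what is new or still open speak of the compounds shown alone.

Compound 1 `COc1ccc(CN(C(=O)Cn2cc(COc3ccc4c(C)cc(=O)oc4c3)nn2)c2cc(OC)c(OC)c(OC)c2)cc1`: 1740 nM
Compound 2 `COc1ccc(CN(C(=O)Cn2cc(CSc3nc4ccccc4s3)nn2)c2cc(OC)c(OC)c(OC)c2)cc1`: 49200 nM
Compound 3 `COc1ccc(CN(C(=O)Cn2cc(CSc3nnc(-c4ccccc4)c(-c4ccccc4)n3)nn2)c2cc(OC)c(OC)c(OC)c2)cc1`: 21800 nM

All three compounds were measured in a functional assay on HepG2 cells (Homo sapiens) for antiproliferative activity, read by MTT assay, with a stated time of 48 h; a lower number here means a stronger inhibitor, a higher number a weaker inhibitor. Compound 2 gives the highest of the three numbers, which makes it the weakest of them. Compound 3 is its nearest neighbour and compound 1 its furthest, both beyond the scatter. Compound 4 `COc1ccc(CN(C(=O)Cn2cc(CSc3nncs3)nn2)c2cc(OC)c(OC)c(OC)c2)cc1` has not yet been measured. It differs from compound 2 in one place, with 1,3,4-thiadiazol-2-yl in place of 1,3-benzothiazol-2-yl on a sulfur. Among the compounds with values here, no measured pair differs in only one place, so the data offer no direct guide to this change. Since compound 2 at 49200 nM sits at the top of the numbers in this assay, a moderate move to a lower number is expected rather than a further rise. The expected step is a 2.5-fold lower number from compound 2 to compound 4 (0.39 log units; beyond the scatter). Compound 4 is estimated at 20000 nM, with an expected range from 6000 nM to 70000 nM.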

Compound 4, half-maximal inhibitory concentration: 38600 nM
The estimate for compound 4 lay 1.9-fold (0.29 log units) below the measured number; the range from low to high includes it.
By their numbers in this assay, from the lowest: compound 1; then compounds 3, 4 and 2 (each within the scatter of the next, the first and the last beyond it).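

In this assay, within the data shown here, the exchange of 1,3-benzothiazol-2-yl for 1,3,4-thiadiazol-2-yl on a sulfur gives a 1.3-fold lower number from compound 2 to compound 4 (0.11 log units; within the scatter), the only comparison in this set that isolates a single place. At this position, then, going from a group of 9 heavy atoms to one of 5, and losing the six-membered aromatic ring of carbon only, leaves the read-out within the scatter, so that ring is not needed to keep the number of compound 2. No measurement shown here bears on why the two compounds read alike.

The compounds shown leave open whether an amine or a carboxylic acid carried on the 1,3,4-thiadiazol-2-yl ring would shift the number. They also leave open what replacing the sulfur with oxygen in compound 4 would do.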